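Cyclopropyl to ethyl at the saturated ring carbon

The source may report more compounds than this note shows. Statements on the series, on what has been measured and on what is new or still open speak of the compounds shown alone.

Measured compounds:
compound 1 `CC(=O)N[C@@H]1CCCc2c1cncc2N1C(=O)c2ccc(Cl)cc2[C@@H]1C1CC1` gives 354 nM
compound 2 `CCS(=O)(=O)NCc1cncc(N2C(=O)c3ccc(Cl)cc3C2(C)C)c1` gives 92 nM

Both values come from an assay on cells for inhibition of cytochrome P450 11B2, mitochondrial (Homo sapiens), read by HTRF; a higher number here means a weaker inhibitor, a lower number a stronger inhibitor. Compound 1 holds the highest of the two numbers; compound 2 sits lower, and the gap between the two lies beyond the usual scatter. Within the data shown here, the two compounds differ in more than one place, so no single step connects them and nothing is said here about what drives that gap.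

Compound 3 `CC[C@H]1c2cc(Cl)ccc2C(=O)N1c1cncc2c1CCC[C@H]2NC(C)=O` is the next compound to be measured in this assay. Compared with compound 1 the change is ethyl in place of cyclopropyl on a saturated ring carbon, with the rest of the shared core unchanged. Among the measured compounds shown here, no measured pair in this set shows this change, so the size of the step is unknown. The estimate rests on compound 1 alone, and the expected step of a 1.1-fold higher number from compound 1 to compound 3 (0.05 log units; within the scatter) is small, no change beyond the scatter, in either direction. Compound 3 is expected to give 400 nM, with a range from 150 nM to 1100 nM.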

Compound 3, half-maximal inhibitory concentration: 97 nM
Compound 3: middle estimate off by 4.1-fold (0.62 log units), on the high side; the whole stated range lies above it.
By their numbers in this assay, from the lowest: compounds 2 and 3 (each within the scatter of the next); then compound 1.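

In this assay, placing ethyl in place of cyclopropyl on the saturated ring carbon of the five-membered non-aromatic ring gives a 3.6-fold lower number from compound 1 to compound 3 (0.56 log units; beyond the scatter) and shows that this position, next to the ring nitrogen, is sensitive to the group it carries. The change is a modest one on paper: the three-membered ring leaves and the substituent goes from 3 heavy atoms to 2, while neither group carries a hydrogen-bond donor, a hydrogen-bond acceptor or a net charge, so the step arises with those counts unchanged. No measurement at hand accounts for the size or direction of this step.

A single pair cannot separate the loss of the three-membered ring from the loss of a carbon, and methyl, isopropyl or a longer chain on this carbon would bear on that question. Also open, as far as these compounds go, are whether an amine or a carboxylic acid is tolerated on this carbon and whether the exchange of cyclopropyl for ethyl gives a similar step on a different core.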